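The source may hold more compounds than are shown below. What is called first, only, known or untested is meant among the compounds shown, and "the series" means these compounds.

Two compounds of the series carry numbers in a functional assay (trachea) with Cavia porcellus as the target; on this read-out lower numbers stand for stronger inhibition and higher numbers for weaker inhibition. Compound 1 `CCn1nc(-n2ccnc2)c2ccccc2c1=O` gives 5370 nM. Compound 2 `CCn1nc(-c2cncs2)c2ccccc2c1=O` gives 562 nM, the lowest of the two numbers; the one step shown, a 9.6-fold lower number from compound 1 to compound 2 (0.98 log units; beyond the scatter), lies beyond the scatter. Compound 3 `CCn1nc(-c2cncnc2)c2ccccc2c1=O` is not yet measured. It differs from compound 2 in one place: pyrimidin-5-yl in place of 1,3-thiazol-5-yl on an aromatic carbon. Among the measured compounds shown here, the single measured step concerns a different exchange at the same place, from 1H-imidazol-1-yl to 1,3-thiazol-5-yl, and shows only that a change of the ring there moves the number by a modest amount; no measured pair exchanges a five-membered for a six-membered aromatic ring, so the direction for compound 3 rests on no close precedent. A small loss, not clearly beyond the scatter, is expected, the expected step being a 2.0-fold higher number from compound 2 to compound 3 (0.29 log units; within the scatter). Compound 3 is therefore estimated at 1100 nM, with a range from 300 nM to 4000 nM.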

Compound 3, half-maximal inhibitory concentration: 9550 nM
Beside the measured number, compound 3's estimate is 8.7-fold (0.94 log units) below it; measured number outside the range, above it.
By their numbers in this assay, from the lowest: compound 2; then compounds 1 and 3 (each within the scatter of the next).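

In this assay the ring on this aromatic carbon matters more than the earlier step could show: a 17-fold higher number from compound 2 to compound 3 (1.23 log units; beyond the scatter) is a large step, beyond the scatter, though the leaving and entering rings match in their counts of hetero atoms, donors and acceptors. Against that, a 1.8-fold higher number from compound 1 to compound 3 (0.25 log units; within the scatter) stays within the scatter, so of the three rings only 1,3-thiazol-5-yl stands apart, with its steps to both others beyond the scatter. Ring size alone does not sort the series: compound 1, with a five-membered ring, goes against such a split by sitting within the scatter of compound 3, with a six-membered ring.

Nothing available accounts for the position of 1,3-thiazol-5-yl. Open, as far as these compounds go, is whether a thiophene, a plain phenyl ring or an amine at this place would hold the number of compound 2, and whether a longer chain can replace the ethyl group.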